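The source may report more compounds than this note shows. Statements on the series, on what has been measured and on what is new or still open speak of the compounds shown alone.

Series notes. In an ADME assay on L6 cells (Rattus norvegicus) for cytotoxicity, read by resazurin assay, with a stated time of 72 h (a higher number here means a weaker inhibitor, a lower number a stronger inhibitor), compound 2 `N/C(CC(O)c1cccc2ccccc12)=N\N=C\c1cccc(Br)c1` gives 3900 nM, the lowest of the three numbers. Compound 3 `N/C(CC(O)c1ccc2ccccc2c1)=N\N=C\c1ccc(F)cc1F` gives 93000 nM in this assay, and compound 1 `N/C(CC(O)c1ccc2ccccc2c1)=N\N=C\c1ccc(Cl)c(Cl)c1` gives 100000 nM; both stand beyond the scatter from compound 2. Among the measured compounds shown here, the only measured step that bears on the change, a 1.1-fold lower number from compound 1 to compound 3 (0.03 log units; within the scatter), shows that 2,4-difluorophenyl in place of 3,4-dichlorophenyl left the number unchanged on the core of compound 1. Compound 4 `N/C(CC(O)c1cccc2ccccc12)=N\N=C\c1ccc(F)cc1F` differs from compound 2 by 2,4-difluorophenyl in place of 3-bromophenyl on a carbon with a double bond to nitrogen. For the measured compounds named here, no measured pair compares 3-bromophenyl with 2,4-difluorophenyl on the core of compound 2, so the step of a 3.1-fold higher number from compound 2 to compound 4 (0.49 log units; beyond the scatter) is expected only as a modest rise in the number, with wide uncertainty. Compound 4 is therefore estimated at 12000 nM, within 2500 nM to 60000 nM.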

Compound 4, half-maximal inhibitory concentration: 4200 nM
For compound 4 the middle estimate is 2.9-fold (0.46 log units) above the measured one; low and high end bracket the measured number.
By their numbers in this assay, from the lowest: compounds 2 and 4 (each within the scatter of the next); then compounds 3 and 1 (each within the scatter of the next).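

In this assay the change to 2,4-difluorophenyl from 3-bromophenyl gives a 1.1-fold higher number from compound 2 to compound 4 (0.03 log units; within the scatter) and so the low number of compound 2 does not rest on 3-bromophenyl alone. With 2,4-difluorophenyl held fixed, compound 4 gives 4200 nM while compound 3 gives 93000 nM on its own core, so in this pair the gap goes with the core and not with the aryl group. Nothing measured here explains either result.

Still open, from the compounds shown here alone, is how the number responds on either core when this position carries a phenyl bearing an amine or a carboxylic acid.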